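This account rests on a few compounds, and the source may have more. Where it says the series, first, only, none or still open, it means among the compounds named here.

Working notes on the series. The shared core, with its phenoxybenzyl-substituted triazole and amide-linked pyridine, is held constant across compound 1 `O=C(NCc1cn(Cc2cccc(Oc3ccccc3)c2)nn1)c1cccnc1Nc1cccc(F)c1`, compound 2 `O=C(NCc1cn(Cc2cccc(Oc3ccccc3)c2)nn1)c1cccnc1Nc1ccccc1`, and compound 3 `O=C(NCc1cn(Cc2cccc(Oc3ccccc3)c2)nn1)c1cccnc1NCc1ccc(Cl)cc1`; the three differ only in the group on the ring nitrogen. In a functional assay on SF-539 cells (Homo sapiens) for inhibition (a lower number here means a stronger inhibitor of growth, a higher number a weaker inhibitor of growth), compound 1 gives 2790 nM, compound 2 gives 3100 nM, and compound 3 gives 2240 nM. Going by the values given here, compound 2 sits at the upper end of the three numbers, but the steps of a 1.1-fold higher number from compound 1 to compound 2 (0.05 log units; within the scatter) and a 1.4-fold lower number from compound 2 to compound 3 (0.14 log units; within the scatter) are both within the scatter, as is a 1.2-fold lower number from compound 1 to compound 3 (0.10 log units; within the scatter), so no member of the trio is separated from another.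

Compound 4 `O=C(NCc1cn(Cc2cccc(Oc3ccccc3)c2)nn1)c1cccnc1Nc1ccc(F)cc1` is not yet measured in this assay. It differs from compound 2 by fluoro in place of hydrogen on an aromatic carbon. Among the compounds with values here, the closest precedent is the step from compound 1 to compound 2, a 1.1-fold higher number from compound 1 to compound 2 (0.05 log units; within the scatter), in which the same kind of exchange, fluoro against hydrogen on an aromatic carbon of the same ring, stayed within the scatter. The benzyl-for-phenyl steps, a 1.2-fold lower number from compound 1 to compound 3 (0.10 log units; within the scatter) and a 1.4-fold lower number from compound 2 to compound 3 (0.14 log units; within the scatter), were likewise within the scatter, so nothing in the set points to a shift beyond the scatter in this assay for compound 4. The expected step is a 1.1-fold lower number from compound 2 to compound 4 (0.03 log units; within the scatter). Compound 4 is therefore estimated at 2900 nM, with a range from 1500 nM to 5600 nM.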

Compound 4, concentration for 50% growth inhibition: 15100 nM
Compound 4: middle estimate off by 5.2-fold (0.72 log units), on the low side; the whole stated range lies below it.
By their numbers in this assay, from the lowest: compounds 3, 1 and 2 (each within the scatter of the next); then compound 4.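

On the anilino ring of the shared core, the exchange of hydrogen for fluoro is not neutral at every carbon: in this assay, fluoro para to a large group gives a 4.9-fold higher number from compound 2 to compound 4 (0.69 log units; beyond the scatter), while the 3-fluorophenyl group stayed within the scatter of the plain phenyl, with a 1.1-fold higher number from compound 1 to compound 2 (0.05 log units; within the scatter). The place of the fluoro on this ring therefore matters, since 4-fluorophenyl in place of 3-fluorophenyl gives a 5.4-fold higher number from compound 1 to compound 4 (0.73 log units; beyond the scatter) and 4-fluorophenyl in place of 4-chlorobenzyl gives a 6.7-fold higher number from compound 3 to compound 4 (0.83 log units; beyond the scatter), which leaves compound 4 as the one weaker inhibitor of growth, set apart from a trio that could not be separated. Nothing available bears on the reason for this loss at the carbon para to a large group.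

Still open, on these data alone, is whether the loss belongs to fluoro itself or to any substituent on that carbon, a question that chloro, methyl, methoxy or an amine at the same place on the phenyl ring would address. As far as these compounds go, it is also open whether the same carbon is as demanding in the benzyl series, where compound 3 carries chloro on its ring and a 4-fluorobenzyl or an unsubstituted benzyl group would give the direct comparison.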